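The source may hold more compounds than are shown below. What is called first, only, known or untested is meant among the compounds shown, and "the series" means these compounds.

Compound 1 `CCOc1cc(=O)oc2cc(OCc3cccc(Cl)c3)ccc12`: 2%
Compound 2 `CC(C)Oc1cc(=O)oc2cc(OCc3cccc(Cl)c3)ccc12`: 3%
Compound 3 `CCOC(=O)COc1cc(=O)oc2cc(OCc3cccc(Cl)c3)ccc12`: 0%

Three compounds sharing one core were tested in an assay on isolated protein (strain Sprague-Dawley) for inhibition of Amine oxidase [flavin-containing] A (Rattus norvegicus), read by spectrophotometry, with a stated time of 5 min, tested at 10 uM; on this read-out lower numbers stand for less inhibition and higher numbers for more inhibition at the one concentration tested (going by the name of the read-out). All three gave small numbers. Compound 3 gives 0%, and its nearest neighbour on the numbers is compound 1, separated by a number 2 percentage points lower from compound 1 to compound 3 (within the scatter), while the furthest is compound 2, separated by a number 3 percentage points lower from compound 2 to compound 3 (within the scatter); both gaps lie within the usual scatter of repeated measurements, so the three compounds cannot be told apart by this read-out.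

Compound 4 `O=C(O)COc1cc(=O)oc2cc(OCc3cccc(Cl)c3)ccc12` has not yet been measured. It differs from compound 3 in one place: hydrogen in place of ethyl on an oxygen next to a carbonyl group. Among the compounds with values here, the steps that bear on this change are those that altered the same region of the molecule, the one from compound 1 to compound 3 and the one from compound 2 to compound 3, and both were within the scatter, as was a number 1 percentage points higher from compound 1 to compound 2 (within the scatter). Every change tried so far at this position has left the read-out essentially flat, and nothing in the three values points to a different outcome here. Compound 4 is therefore expected to show a number 2 percentage points higher from compound 3 to compound 4 (within the scatter), a step not beyond the scatter. Compound 4 is estimated to give 2%, with a range from 0% to 12%.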

Compound 4, a percentage reported as inhibition, at one concentration (the size of the read-out at that concentration, not a potency): 0%
The estimate for compound 4 lay 2 percentage points above the measured number, and the stated range covers the measured number.
By their numbers in this assay, from the lowest: compounds 3, 4, 1 and 2 (each within the scatter of the next).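

Swapping ethyl for hydrogen turns the ethoxycarbonyl end of the side chain into a carboxy end, and in this assay this gives no change at the digits printed from compound 3 to compound 4 (within the scatter), so the free carboxy group and its ethyl ester cannot be told apart here. The carboxymethyl side chain also stays within the scatter of the two plain ether side chains, with a number 3 percentage points lower from compound 2 to compound 4 (within the scatter) and a number 2 percentage points lower from compound 1 to compound 4 (within the scatter), which extends the flat picture from the ester to a carboxy-ended chain on the same oxygen. No measurement is available that would explain this flat result.

All four compounds sit so close together that this position has yet to produce a difference beyond the scatter in this assay, and a single test concentration gives no potency for any of them. Still open, as far as these compounds go, is whether an amine or a primary amide at the end of the side chain, or a longer chain between the ring oxygen and the carboxy group, would give a number that stands clear of these four.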